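Cytotoxicity limits in a pyrrole amide series

The source may report more compounds than this note shows. Statements on the series, on what has been measured and on what is new or still open speak of the compounds shown alone.

Measured compounds, with the read-out in an ADME assay on HEK-293T cells (Homo sapiens) for cytotoxicity, read by MTT assay, with a stated time of 72 h; a higher number here means a weaker inhibitor, a lower number a stronger inhibitor:
Compound 1 `CCc1nnc(NC(=O)Cn2c(-c3ccccc3)cc(-c3ccccc3)c2-c2ccco2)s1`: compound 1 gives < 50000 nM, a limit of the assay.
Compound 2 `CCc1nnc(NC(=O)Cn2c(-c3ccccc3)cc(-c3ccco3)c2-c2ccco2)s1`: compound 2 gives < 50000 nM, a limit of the assay.
Compound 3 `O=C(Cn1c(-c2ccccc2)cc(-c2cccc3ccccc23)c1-c1ccco1)Nc1nc2ccccc2s1`: compound 3 gives < 50000 nM, a limit of the assay.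

Compound 3 stands at the limit of this assay, and the two other values shown stand at the same limit; none of the three is a number. Going by the values given here, the one single-site step that can be traced, a step that the two limits leave unreadable from compound 1 to compound 2, is the replacement furan-2-yl in place of phenyl on an aromatic carbon, and its size cannot be read since both ends are limits. The bearing piece of evidence is the limit of < 50000 nM in this assay, at which 3 of the 3 values shown sit.

Compound 4 `CCc1nnc(NC(=O)Cn2c(-c3ccccc3)cc(-c3cccc4ccccc34)c2-c2ccco2)s1` differs from compound 3 by 5-ethyl-1,3,4-thiadiazol-2-yl in place of 1,3-benzothiazol-2-yl on an amide-type nitrogen. Among the compounds with values here, no measured step concerns this change on the amide-type nitrogen, so no direction can be read from the series. Given that every value so far sits at the limit, compound 4 is expected to sit there as well, an expected step that the limit leaves unreadable from compound 3 to compound 4 in this assay that amounts to no change beyond the scatter. Compound 4 is therefore estimated at 30000 nM, with a range from 6000 nM to 50000 nM, most likely reported as a limit.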

Compound 4, half-maximal inhibitory concentration: < 50000 nM
Compound 4 was reported as a limit; the forecaster's own chance of this, stated with the estimate: 85%; the middle value lies beyond the limit too.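

Going by these compounds alone, compound 4 is also reported as a limit, so its steps from compound 1, compound 2 and compound 3 in this assay cannot be read, and no new step emerges. The compounds shown leave open where any of them would fall as a number, and whether changing the group on the amide-type nitrogen or on the aromatic carbon alters the read-out.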